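Swapping a Hydroxyl-Bearing Chain for an Isobutyl Chain

The source may hold more compounds than are shown below. What is called first, only, known or untested is meant among the compounds shown, and "the series" means these compounds.

Of the compounds shown here, two sharing a core have been measured in an assay on CHO cells for displacement of a labelled ligand from prostaglandin D2 receptor 2 (Homo sapiens), read by scintillation counting; on this read-out lower numbers stand for stronger inhibition and higher numbers for weaker inhibition. Compound 1 `Cc1ccc(S(=O)(=O)CCO)cc1C#Cc1cc(Cl)ccc1OCC(=O)O` gives 19 nM in this assay. Compound 2 `CCCS(=O)(=O)c1ccc(C)c(C#Cc2cc(Cl)ccc2OC(CC)C(=O)O)c1` gives 30 nM in this assay, and the two numbers lie within the usual scatter of each other, so neither can be set apart from the other. Among the measured compounds shown here, no step between two measured compounds differing in a single place is available.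

Compound 3 `Cc1ccc(S(=O)(=O)CC(C)C)cc1C#Cc1cc(Cl)ccc1OCC(=O)O` has not yet been measured in this assay. It differs from compound 1 in one place: isopropyl in place of hydroxymethyl on a saturated chain carbon bound to a sulfonyl sulfur. Compound 2, whose chain on the sulfonyl sulfur also carries no hydroxyl, gives 30 nM in this assay, which suggests the hydroxyl is not decisive here. The step expected a 1.5-fold higher number from compound 1 to compound 3 (0.17 log units; within the scatter) is therefore small, within the scatter, if anything toward a slightly higher number. Compound 3 is expected to give 28 nM in this assay, within 9 nM to 90 nM.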

Compound 3, inhibition constant: 3 nM
For compound 3 the middle estimate is 9.3-fold (0.97 log units) above the measured one; measured number below the stated range.
By their numbers in this assay, from the lowest: compound 3; then compounds 1 and 2 (each within the scatter of the next).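

Among the compounds shown here, the step of a 6.3-fold lower number from compound 1 to compound 3 (0.80 log units; beyond the scatter) in this assay is the first direct reading of this position, since it comes from two compounds that differ in one place only. It shows that the group on this saturated chain carbon influences the read-out, and that on the shared core the 2-hydroxyethyl chain can give way to the isobutyl chain with a lower number, not a higher one. Nothing available explains this step, so its cause remains unknown.

The change removes the hydroxyl and introduces a branched end at the same time, so these compounds cannot show which of the two matters more. Also open, as far as these compounds go, is how a straight butyl chain, a longer chain or a chain ending in an amine would behave at this position.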